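Amide to urea change on the anilide of compound 2

The compounds below may be only part of what the source reports. "The series", "measured", "known", "first", "only" and "open" are said of these compounds alone.

Compound 1 `COc1cc(-c2nn(-c3cccc(NC(=O)c4cccc(C(F)(F)F)c4)c3)cc2-c2ccncc2)ccc1Cl` carries a benzamide on the shared core. In a functional assay on HT-29 cells (Homo sapiens) for inhibition, read by sulforhodamine B assay, with a stated time of 48 h (a lower number here means a stronger inhibitor of growth, a higher number a weaker inhibitor of growth), compound 1 gives 20100 nM. Compound 2 `COc1cc(-c2nn(-c3cccc(NC(=O)c4ccc(Cl)c(C(F)(F)F)c4)c3)cc2-c2ccncc2)ccc1Cl` differs from it by chloro in place of hydrogen on an aromatic carbon. In this assay compound 2 reports only a limit, > 32500 nM. This step, an at least 1.6-fold higher number from compound 1 to compound 2 (0.20 log units; that floor lies within the scatter), is the only measured one in the set, and its floor lies within the scatter; compound 2 stands at the limit of > 32500 nM in this assay, at which 1 of the 2 values shown sits, so no number is known for it in this assay.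

Compound 3 `COc1cc(-c2nn(-c3cccc(NC(=O)Nc4ccc(Cl)c(C(F)(F)F)c4)c3)cc2-c2ccncc2)ccc1Cl` changes the link between the two aryl groups: (4-chloro-3-(trifluoromethyl)phenyl)amino in place of 4-chloro-3-(trifluoromethyl)phenyl on a carbonyl carbon, turning the amide into a urea. Going by the values given here, no measured step touches this carbonyl position, so nothing bears directly on the change. With compound 2 already at the limit, the expected step of a number no higher from compound 2 to compound 3 (the limit leaves the size open) is none beyond the scatter, and a result that again reaches only the limit is considered likely. Compound 3 is therefore estimated at 32500 nM, with the expected range running from 10000 nM to 100000 nM.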

Compound 3, concentration for total growth inhibition: 4450 nM
Beside the measured number, compound 3's estimate is 7.3-fold (0.86 log units) above it, outside the stated range (below it).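

Going by these compounds alone, the carbonyl position now has a reading of its own: in this assay, the amide-to-urea change gives an at least 7.3-fold lower number from compound 2 to compound 3 (0.86 log units; beyond the scatter), the first step beyond the scatter, and the printed size is only a floor. As far as these compounds go, the true size stays open, and compound 2 sets that floor with a limit rather than a number: the limit of > 32500 nM in this assay, at which 1 of the 3 values shown sits. The urea also stands clear of the benzamide that lacks the chloro, with a 4.5-fold lower number from compound 1 to compound 3 (0.65 log units; beyond the scatter), so compound 3 has the lowest number of the three, though this comparison swaps 3-(trifluoromethyl)phenyl for (4-chloro-3-(trifluoromethyl)phenyl)amino and so cannot separate the amino link from the chloro.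

The compounds shown leave open whether the urea link would lower the number equally with a plain 3-(trifluoromethyl)phenyl group on the amino nitrogen, since every urea here carries the chloro. They also leave open whether the amino nitrogen itself matters, a question that an oxygen (a carbamate), a methylene or an N-methyl urea at that place would address.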